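This account rests on a few compounds, and the source may have more. Where it says the series, first, only, none or still open, it means among the compounds named here.

Measured so far:
compound 1, `Brc1cccc2c1nnn2CC1CC1`: 1.3 mL/min/g
compound 2, `Brc1cc(Br)c2nnn(CC3CC3)c2c1`: 0.6 mL/min/g
compound 3, `Clc1cc(Br)c2nnn(CC3CC3)c2c1`: 0.5 mL/min/g

In an ADME assay on microsomes from liver (Homo sapiens) for metabolic stability, tested at 2.5 uM (a higher number here means faster removal of the compound, a lower number slower removal), compound 1 has the highest number of the three. The core of compound 2 differs from that of compound 1 by hydrogen in place of bromo on an aromatic carbon; the step is a 2.2-fold lower number from compound 1 to compound 2 (0.34 log units; beyond the scatter), and a related step is a 2.6-fold lower number from compound 1 to compound 3 (0.41 log units; beyond the scatter). Between the two substituted compounds the change is chloro in place of bromo on an aromatic carbon, and that step is a 1.2-fold lower number from compound 2 to compound 3 (0.08 log units; within the scatter).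

Compound 4, `Clc1cccc2c1nnn2CC1CC1`, is not yet measured in this assay. It differs from compound 1 by chloro in place of bromo on an aromatic carbon. Compared with the change from compound 2 to compound 3, the place differs: there it was meta to a bromo group, meta to a fused ring and para to a fused ring, here it is ortho to a fused ring and meta to a fused ring, so this is the same kind of change, not the same change.

From compound 1 to compound 4 the expected step is a 1.2-fold lower number from compound 1 to compound 4 (0.07 log units; within the scatter), because the same kind of change gave a 1.2-fold lower number from compound 2 to compound 3 (0.08 log units; within the scatter). Compound 4 is therefore expected to give about 1.1 mL/min/g, likely between 0.6 mL/min/g and 2 mL/min/g.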

Compound 4, intrinsic clearance in a liver preparation (reported as CLH), per the amount of preparation that the assay uses: 4.2 mL/min/g
Compound 4: the middle estimate sits 3.8-fold (0.58 log units) below what was measured; the whole stated range lies below it.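

In this assay, chloro in place of bromo on an aromatic carbon does not carry over unchanged between the two cores: on the core of compound 1, at the carbon ortho to a fused ring and meta to a fused ring, the exchange gives a 3.2-fold higher number from compound 1 to compound 4 (0.51 log units; beyond the scatter). Set beside the earlier step, the result differs from it: the same change on two cores in this assay, a 1.2-fold lower number (0.08 log units; within the scatter) from compound 2 to compound 3 and a 3.2-fold higher number (0.51 log units; beyond the scatter) from compound 1 to compound 4, 3.9-fold (0.59 log units) apart, beyond the scatter of two such steps

This shows that, in this series, a step for this exchange read on one core is not a safe estimate for the other, but it does not show why. The two pairs differ both in where the exchange sits and in the rest of the substitution, and a single pair on each side cannot separate these.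

The compounds shown carry only bromo and chloro on the aromatic ring, so the behaviour of fluoro, a nitrile or an amine at that aromatic carbon remains open. Also open, as far as these compounds go, is whether the gap between the two steps persists with a longer chain in place of the cyclopropylmethyl group.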